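Series notes: aryl sulfonamide thioesters, cytotoxicity on U226 cells

The source may report more compounds than this note shows. Statements on the series, on what has been measured and on what is new or still open speak of the compounds shown alone.

Measured so far:
compound 1 `COCCCOc1ccc(S(=O)(=O)Nc2ccc(C(=O)CSC(C)=O)cn2)cc1` gives 29000 nM in a functional assay on U226 cells (Homo sapiens) for cytotoxicity; on this read-out higher numbers stand for an effect only at larger amounts of compound and lower numbers for an effect already at smaller amounts
compound 2 `CC(=O)SCC(=O)c1ccc(NS(=O)(=O)c2ccc(OCCCN3CCCCC3)cc2)nc1` gives 800 nM in this assay

For the measured compounds named here, compound 2 holds the lowest number of the two; the only step so far, a 36-fold lower number from compound 1 to compound 2 (1.56 log units; beyond the scatter), is large. Compound 3 `CC(=O)SCC(=O)c1ccc(NS(=O)(=O)c2ccc(OCCCCN(C)C)cc2)nc1` differs from compound 2 by (dimethylamino)methyl in place of piperidin-1-yl on a saturated chain carbon, three bonds along the chain from an oxygen on an aromatic ring. Going by the values given here, no measured step covers this exchange directly; the step from compound 1 to compound 2 bears on it only in that both groups entering carry a nitrogen, so it gives no direction. Compound 3 is expected to stay close to compound 2, with a 1.3-fold higher number from compound 2 to compound 3 (0.10 log units; within the scatter) inside the scatter. The estimate for compound 3 is 1000 nM, range 400 nM to 2500 nM.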

Compound 3, half-maximal effective concentration: 120 nM
Compound 3: the middle estimate sits 8.3-fold (0.92 log units) above what was measured, outside the stated range (below it).
By their numbers in this assay, from the lowest: compound 3; then compound 2; then compound 1.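

In this assay this position responds not only to the presence of a nitrogen group but also to its form: 4-(dimethylamino)butyl in place of 3-(piperidin-1-yl)propyl gives a 6.7-fold lower number from compound 2 to compound 3 (0.82 log units; beyond the scatter). Starting from the methoxy group, the same position gives a 240-fold lower number from compound 1 to compound 3 (2.38 log units; beyond the scatter). Nothing available explains either step.

The step from compound 2 to compound 3 changes both the chain length and the amine, and the two contributions remain unseparated. Open, on these data alone, are 3-(dimethylamino)propyl and 4-(piperidin-1-yl)butyl, which would separate them, and a morpholine or carboxylic acid at the chain end.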